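A few compounds are considered here, and "the series" means these few. Any claim that something is new, unique, unknown or untested is made for them only; others in the source may bear on it.

Measured so far:
compound 1 `CC1=CC[C@@H]([C@@](C)(O)CCCC(C)(C)NC(=S)N/N=C\c2ccccc2)CC1` – 38400 nM
compound 2 `CC1=CC[C@@H]([C@@](C)(O)CCCC(C)(C)NC(=S)N/N=C\c2ccc(O)cc2)CC1` – 1460 nM

Going by the values given here, in a functional assay on NCI-H460 cells (Homo sapiens) for cytotoxicity, read by sulforhodamine B assay (on this read-out lower numbers stand for stronger inhibition of growth and higher numbers for weaker inhibition of growth), compound 2 holds the lower of the two numbers; the single step of a 26-fold lower number from compound 1 to compound 2 (1.42 log units; beyond the scatter) is large and beyond the scatter. Compound 3 `CC1=CC[C@@H]([C@@](C)(O)CCCC(C)(C)NC(=S)N/N=C\c2ccc(N(C)C)cc2)CC1` differs from compound 2 by dimethylamino in place of hydroxy on an aromatic carbon. Among the compounds with values here, no measured step exchanges one aromatic substituent for another; the only step known concerns adding hydroxy to the bare ring, and it says little about whether dimethylamino will match hydroxy. The step from compound 2 to compound 3 is therefore expected to be small or none beyond the scatter, a 1.7-fold higher number from compound 2 to compound 3 (0.23 log units; within the scatter), with the range opened wide. For compound 3 the estimate is 2500 nM, between 600 nM and 12000 nM.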

Compound 3, concentration for 50% growth inhibition: 19600 nM
Estimate against measurement, compound 3: 7.8-fold (0.89 log units) below, outside the stated range (above it).
By their numbers in this assay, from the lowest: compound 2; then compounds 3 and 1 (each within the scatter of the next).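

In this assay, the group on this aromatic carbon is not interchangeable: dimethylamino in place of hydroxy gives a 13-fold higher number from compound 2 to compound 3 (1.13 log units; beyond the scatter). Against the bare ring, dimethylamino gives a 2.0-fold lower number from compound 1 to compound 3 (0.29 log units; within the scatter), so among these compounds the gain belongs to hydroxy and does not extend to the other group. Nothing at hand accounts for this difference.

The compounds shown leave open whether the gain is tied to hydroxy alone, or whether methoxy or a primary amine on the same aromatic carbon would keep it.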